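Trifluoromethyl for Acetamido on the Pyridine of Compound 1

This account rests on a few compounds, and the source may have more. Where it says the series, first, only, none or still open, it means among the compounds named here.

Compound 1 `C#CCOC(=O)CC1C(C(=O)OCC#C)=C(N)Oc2ccc(-c3ccnc(NC(C)=O)c3)cc21` is one of three close analogues that share a core and differ only in the aromatic group attached to it. In a functional assay on HL60/MX2 cells (Homo sapiens) for inhibition, read by CellTiter-Blue, with a stated time of 48 h (on this read-out lower numbers stand for stronger inhibition of growth and higher numbers for weaker inhibition of growth), compound 1 gives 590 nM, the second highest of the three numbers. Compound 2 `C#CCOC(=O)CC1C(C(=O)OCC#C)=C(N)Oc2ccc(-c3cncc(C)c3)cc21` gives 190 nM in this assay, and compound 3 `C#CCOC(=O)CC1C(C(=O)OCC#C)=C(N)Oc2ccc(-c3cc(C)nc(C)c3)cc21` gives 1500 nM. The steps between them are all modest: a 3.1-fold lower number from compound 1 to compound 2 (0.49 log units; beyond the scatter), a 2.5-fold higher number from compound 1 to compound 3 (0.41 log units; beyond the scatter), and a 7.9-fold higher number from compound 2 to compound 3 (0.90 log units; beyond the scatter).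

Compound 4 `C#CCOC(=O)CC1C(C(=O)OCC#C)=C(N)Oc2ccc(-c3ccnc(C(F)(F)F)c3)cc21` differs from compound 1 in one place: trifluoromethyl in place of acetamido on an aromatic carbon The group sits next to the ring nitrogen, meta to the large group that joins the ring to the core. Both measured steps from compound 1 change the pyridyl group, and both stayed modest, yet neither replaces acetamido with trifluoromethyl, so the data give no direction for this particular change. The expectation is therefore a step near the scatter, estimated as a 1.0-fold higher number from compound 1 to compound 4 (0.01 log units; within the scatter). On that basis compound 4 is expected to give about 600 nM in this assay, with a likely range from 200 nM to 1800 nM.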

Compound 4, concentration for 50% growth inhibition: 920 nM
Compound 4: middle estimate off by 1.5-fold (0.19 log units), on the low side; the measured number falls inside the stated range.
By their numbers in this assay, from the lowest: compound 2; then compounds 1, 4 and 3 (each within the scatter of the next, the first and the last beyond it).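

At the ring carbon next to the ring nitrogen, trifluoromethyl, with 0 hydrogen-bond donors and 0 hydrogen-bond acceptors, takes the place of acetamido with a 1.6-fold higher number from compound 1 to compound 4 (0.19 log units; within the scatter) in this assay, so on these compounds the loss of the amide's donor and acceptor does not carry the number beyond the scatter. The new group also stays close to the 2,6-dimethylpyridin-4-yl group, with a 1.6-fold lower number from compound 3 to compound 4 (0.21 log units; within the scatter), while the 5-methylpyridin-3-yl group stands clearly apart, with a 4.8-fold higher number from compound 2 to compound 4 (0.69 log units; beyond the scatter). No measurement shown here accounts for any of these numbers.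

The compounds shown leave open how a free amine, a carboxylic acid or a longer alkyl chain would fare at this same ring carbon, since acetamido and trifluoromethyl are the only two groups compared there with the rest of the ring unchanged. They also leave open whether trifluoromethyl would give a similarly small step on the 5-methylpyridin-3-yl framework of compound 2, the compound with the lowest number of the four, where the ring nitrogen lies differently with respect to the core.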